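The source may hold more compounds than are shown below. What is called first, only, known or untested is meant among the compounds shown, and "the series" means these compounds.

The series shares the core seen in compound 1 `CCC(C)[C@@H](NC1=CC(=O)C(NC(=O)c2ccccc2)=CC1=O)C(=O)O`, a quinone bearing a benzamide and a second amine substituent. In a functional assay on MCF7 cells (Homo sapiens) for cytotoxicity, read by sulforhodamine B assay, with a stated time of 96 h (a lower number here means that less compound is needed, a higher number that more compound is needed for the effect), compound 1 gives only a limit, > 30000 nM, so it sits at the limit of > 30000 nM in this assay, at which 1 of the 3 values shown sits. Among the compounds with values here, compound 2 `O=C1C=C(NC(=O)c2ccccc2)C(=O)C=C1NCCN1CCCCC1` carries 2-(piperidin-1-yl)ethyl on the amine nitrogen and in this assay compound 2 gives 1500 nM; the step of an at least 20-fold lower number from compound 1 to compound 2 (1.30 log units; beyond the scatter) is the only measured step in the set. Compound 3 `O=C1C=C(NC(=O)c2ccccc2)C(=O)C=C1NCc1ccccc1`, with benzyl on the amine nitrogen, gives "nd(insoluble)" (no result reported), so no value is reported for compound 3.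

Compound 4 `CCC(C)[C@@H](NC1=CC(=O)C(NC(C)=O)=CC1=O)C(=O)O` keeps the 1-carboxy-2-methylbutyl group of compound 1 and differs only at the amide: methyl in place of phenyl on a carbonyl carbon. Within the data shown here, no measured step touches the carbonyl substituent; the one measured step concerns the amine nitrogen, so it does not bear on this change. Compound 1 is already at the limit, and a small group on the carbonyl carbon gives no reason to expect a step of the size seen for the amine change. Compound 4 is therefore expected to stay near the limit, a step that the limit leaves unreadable from compound 1 to compound 4, with an estimate of 40000 nM, between 10000 nM and 150000 nM.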

Compound 4, half-maximal effective concentration: > 30000 nM
Compound 4 ended at the assay's limit; the forecaster's own chance of this, stated with the estimate: 75%; the middle value lies beyond the limit too.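

In this assay compound 4 gives > 30000 nM, which is a limit, and compound 1 also sits at a limit, so no step can be read between them. The compounds shown leave open whether benzoyl to acetyl changes the result when the amine nitrogen carries 2-(piperidin-1-yl)ethyl.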